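A few compounds are considered here, and "the series" means these few. Any claim that something is new, unique, unknown or untested is made for them only; others in the source may bear on it.

Measured in a functional assay on DLD-1 cells (Homo sapiens) for cytotoxicity, with a stated time of 48 h; a lower number here means a stronger inhibitor, a higher number a weaker inhibitor:
Compound 1, `C[S+]([O-])/C=C/c1cc(=O)c2cc(Cl)ccc2o1`, gives 6500 nM.
Compound 2, `CCCC(=O)Oc1ccc2oc(/C=C/[S+](C)[O-])cc(=O)c2c1`, gives 8700 nM.
Compound 3, `CCCCCOc1ccc2oc(/C=C/[S+](C)[O-])cc(=O)c2c1`, gives 6600 nM.

Compound 3 sits second highest of the three numbers; the three compounds differ only in the substituent on the shared core, and every step among them stays within the scatter: a 1.3-fold higher number from compound 1 to compound 2 (0.13 log units; within the scatter), a 1.0-fold higher number from compound 1 to compound 3 (0.01 log units; within the scatter), a 1.3-fold lower number from compound 2 to compound 3 (0.12 log units; within the scatter). Compound 4, `CCCCOc1ccc2oc(/C=C/[S+](C)[O-])cc(=O)c2c1`, differs from compound 3 by hydrogen in place of methyl on a saturated chain carbon, four bonds along the chain from an oxygen on an aromatic ring. Within the data shown here, no measured pair shortens this chain, but the substituent swaps above moved this assay by very little, so the shortened chain is expected to change little as well. Compound 4 is therefore estimated at 6600 nM, with a likely range from 3300 nM to 13000 nM. That estimate means no change at the digits printed from compound 3 to compound 4 (within the scatter), a step not expected to exceed the scatter.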

Compound 4, half-maximal inhibitory concentration: 4800 nM
The estimate for compound 4 lay 1.4-fold (0.14 log units) above the measured number; the measured number falls inside the stated range.
By their numbers in this assay, from the lowest: compounds 4, 1, 3 and 2 (each within the scatter of the next).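

In this assay, shortening pentyl to butyl gives a 1.4-fold lower number from compound 3 to compound 4 (0.14 log units; within the scatter), the first step shown that changes only the chain length at this position, and it leaves the number within the scatter. Swapping the group more broadly does no more: a 1.8-fold lower number from compound 2 to compound 4 (0.26 log units; within the scatter) and a 1.4-fold lower number from compound 1 to compound 4 (0.13 log units; within the scatter), so butoxy stays within the scatter of both the ester and chloro compounds. Nothing shown bears on why this position tolerates these changes. Still open, going by these compounds, is whether a much longer chain, a carboxylic acid or an amine on this chain would move the number beyond the scatter.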